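The source may hold more compounds than are shown below. What is called first, only, known or untested is meant among the compounds shown, and "the series" means these compounds.

Compound 3 `N#CC1=C(N)Oc2c(N)cc3nc4ccccc4nc3c2C12C(=O)N(Cc1cnnn1-c1cc(Cl)ccc1Cl)c1ccccc12` stands at the edge of what this study can show. In an ADME assay on HUVEC cells (Homo sapiens) for antiproliferative activity, read by MTT assay, with a stated time of 48 h (on this read-out higher numbers stand for weaker inhibition and lower numbers for stronger inhibition), compound 3 gives > 50000 nM, which is a limit of the assay and not a number. Its two relatives sit at the same place. Compound 1 `CCc1ccccc1-n1nncc1CN1C(=O)C2(C(C#N)=C(N)Oc3c(N)cc4nc5ccccc5nc4c32)c2ccccc21` gives > 50000 nM in this assay, again a limit. Compound 2 `N#CC1=C(N)Oc2c(N)cc3nc4ccccc4nc3c2C12C(=O)N(Cc1cnnn1-c1ccccc1Cl)c1ccccc12` gives > 50000 nM in this assay, also a limit. In other words, (the limit of > 50000 nM in this assay, at which 3 of the 3 values shown sit). The steps among the three therefore have no readable size: a step that the two limits leave unreadable from compound 1 to compound 2, a step that the two limits leave unreadable from compound 1 to compound 3, and a step that the two limits leave unreadable from compound 2 to compound 3.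

Compound 4 `Cc1ccc(-n2nncc2CN2C(=O)C3(C(C#N)=C(N)Oc4c(N)cc5nc6ccccc6nc5c43)c3ccccc32)cc1Cl` has not yet been measured. It differs from compound 3 in one place: 3-chloro-4-methylphenyl in place of 2,5-dichlorophenyl on an aromatic nitrogen. The measured steps that bear on this change are the three just named, each of which alters the group on the aromatic nitrogen of the five-membered ring with three nitrogen, and none of them yields a size because of the limit of > 50000 nM in this assay, at which 3 of the 3 values shown sit. With nothing readable to go on, no step beyond the scatter can be expected in this assay in either direction, and the expected step is a number no higher from compound 3 to compound 4 (the limit leaves the size open). Compound 4 is thus expected to give 50000 nM in this assay, with a range from 20000 nM to 200000 nM, most probably reported once more as a limit.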

Compound 4, half-maximal inhibitory concentration: > 50000 nM
Compound 4: only a limit was reported; the forecaster's own chance of this, stated with the estimate: 85%; the middle value lies on the limit itself.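

No new step can be read for compound 4 against compound 1, compound 2 or compound 3 in this assay, since all four sit at one limit: the limit of > 50000 nM in this assay, at which 4 of the 4 values shown sit.

The compounds shown leave open how far apart these four truly lie and whether any group on this aromatic nitrogen would give a readable value in this assay.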